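This account rests on a few compounds, and the source may have more. Where it says the series, first, only, none or still open, it means among the compounds named here.

In a functional assay on Rec1 cells (Homo sapiens) for inhibition, read by luminescence and CellTiter-Glo, with a stated time of 72 h (on this read-out lower numbers stand for stronger inhibition and higher numbers for weaker inhibition), compound 1 `C/C=C/C(=O)Nc1ccc(Cn2nc(-c3ccc(Oc4ccccc4)cc3)cc2C(=O)O)cc1` gives 23600 nM. Compound 2 `C/C=C/C(=O)Nc1ccc(Cn2nc(-c3ccc(Oc4ccccc4)cc3)cc2C(=O)OCC)cc1` carries ethyl in place of hydrogen on an oxygen next to a carbonyl group, and in this assay compound 2 gives 13100 nM. That change produced a 1.8-fold lower number from compound 1 to compound 2 (0.26 log units; within the scatter). Compound 3 `C=CC(=O)N1CCCC(n2nc(-c3ccc(Oc4ccccc4)cc3)cc2C(=O)O)C1` is built on a different core, and the difference between the two cores is not broken down here. In this assay compound 3 gives 50000 nM, the highest number among the three measured compounds, with compound 1 nearest and compound 2 furthest from it. For the measured compounds named here, compound 4 `C=CC(=O)N1CCCC(n2nc(-c3ccc(Oc4ccccc4)cc3)cc2C(=O)OCC)C1` has not yet been measured; it carries ethyl in place of hydrogen on an oxygen next to a carbonyl group, the same change at the same place as the one that turned compound 1 into compound 2. Going by the values given here, compound 4 is expected to show a step of a 1.7-fold lower number from compound 3 to compound 4 (0.22 log units; within the scatter) because the same change gave a 1.8-fold lower number from compound 1 to compound 2 (0.26 log units; within the scatter) on the other core, and nothing among the measured compounds suggests a different size here, though the core of compound 3 is shared with no other measured compound. Compound 4 is therefore estimated at 30000 nM, with a range from 15000 nM to 60000 nM.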

Compound 4, half-maximal inhibitory concentration: 13800 nM
Estimate against measurement, compound 4: 2.2-fold (0.34 log units) above; the whole stated range lies above it.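

In this assay, putting ethyl in place of hydrogen on an oxygen next to a carbonyl group gives a 3.6-fold lower number from compound 3 to compound 4 (0.56 log units; beyond the scatter) on the core of compound 3. Set beside the earlier step on the other core, this step does not differ from it by more than the usual scatter of two such steps: the same change on two cores in this assay, a 1.8-fold lower number (0.26 log units; within the scatter) from compound 1 to compound 2 and a 3.6-fold lower number (0.56 log units; beyond the scatter) from compound 3 to compound 4, 2.0-fold (0.30 log units) apart, within the scatter of two such steps The change can therefore be read as carrying over between these two cores with a step of one size, but this rests on only two pairs of compounds and shows neither how it would behave on a third core nor why the numbers move as they do.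

The compounds shown leave open whether a methyl, an isopropyl or a benzyl group on the same oxygen would give a step of similar size. Also open, on these data alone, is how a primary amide in place of the carboxylic acid would read in this assay on either core.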